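A Change of Drawn Configuration at One Ring Carbon

A few compounds are considered here, and "the series" means these few. Any claim that something is new, unique, unknown or untested is made for them only; others in the source may bear on it.

Three compounds have been measured in a functional assay on A549 cells (Homo sapiens) for cytotoxicity, read by MTT assay, with a stated time of 48 h; on this read-out lower numbers stand for stronger inhibition and higher numbers for weaker inhibition:

Compound 1, `CCOC(=O)[C@@]1(C(=O)Nc2ccccc2Cl)C[C@H]1c1cc(OC)c(OC)c(OC)c1`, gives 17600 nM.
Compound 2, `COc1cc([C@@H]2C[C@@]2(CO)C(=O)Nc2ccccc2Cl)cc(OC)c1OC`, gives 11400 nM.
Compound 3, `CCOC(=O)[C@@]1(C(=O)Nc2ccccc2)C[C@H]1c1cc(OC)c(OC)c(OC)c1`, gives 65900 nM.

Compound 1 stands second highest of the three numbers. Its nearest neighbour is compound 2, reached by the step of a 1.5-fold lower number from compound 1 to compound 2 (0.19 log units; within the scatter), which places hydroxymethyl in place of ethoxycarbonyl on a saturated ring carbon. Its furthest neighbour is compound 3, reached by the step of a 3.7-fold higher number from compound 1 to compound 3 (0.57 log units; beyond the scatter), which places hydrogen in place of chloro on an aromatic carbon.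

Compound 4, `CCOC(=O)[C@@]1(C(=O)Nc2ccccc2Cl)C[C@@H]1c1cc(OC)c(OC)c(OC)c1`, has not yet been measured. It differs from compound 1 as follows: the two compounds have the same atoms and bonds and differ only in configuration as drawn: 1 of 2 stereo elements differ; a stereocentre at a saturated ring carbon is drawn S in compound 1 and R in compound 4. Neither measured step bears on such a change; both exchange a group and leave every stereocentre as drawn, so the data give no guide to how a change of configuration alone shifts the number. The step from compound 1 to compound 4 is therefore expected to be of uncertain direction, and the estimate is placed near compound 1 with a wide range: a 1.6-fold higher number from compound 1 to compound 4 (0.20 log units; within the scatter). Compound 4 is estimated at 28000 nM, expected to lie between 7000 nM and 110000 nM.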

Compound 4, half-maximal inhibitory concentration: 29000 nM
The estimate for compound 4 lay 1.0-fold (0.02 log units) below the measured number, within the range that was stated.
By their numbers in this assay, from the lowest: compounds 2, 1 and 4 (each within the scatter of the next, the first and the last beyond it); then compound 3.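

Going by these compounds alone, compounds 1 and 4 give the first reading of a change of configuration at this saturated ring carbon in this assay, and the step, a 1.6-fold higher number from compound 1 to compound 4 (0.22 log units; within the scatter), stays within the scatter. Within the data shown here, the two group exchanges among the earlier compounds could not show this: with ethoxycarbonyl and chloro both kept, the S and R drawings at this carbon are not told apart by this read-out, a finding that holds for this one pair only. The comparison tests nothing other than this stereocentre, and no exchange of a group enters into it: the fact that compounds 1 and 4 differ only in the configuration as drawn

The compounds shown leave open whether configuration at this carbon counts for as little with hydroxymethyl in place of ethoxycarbonyl, as in compound 2, or with hydrogen in place of chloro, as in compound 3, and what a change at the second stereocentre would do. They also leave open how a carboxylic acid or an amine in place of ethoxycarbonyl on this saturated ring carbon would read in either configuration.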